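Triazole to isopropylcarbamoylmethyl: stability outlook for compound 3

The compounds below may be only part of what the source reports. "The series", "measured", "known", "first", "only" and "open" are said of these compounds alone.

Compound 2 `CC(C)C(c1nnc[nH]1)c1ccc(-c2ccc3cccc(F)c3c2)[nH]c1=O` stands highest of the two numbers in an ADME assay on microsomes from liver (Homo sapiens) for metabolic stability (on this read-out higher numbers stand for a longer-lived compound and lower numbers for a shorter-lived compound), giving 0.905 h. For the measured compounds named here, compound 1 `CC(C)C(Cc1nnc[nH]1)c1ccc(-c2ccc3cccc(F)c3c2)[nH]c1=O` gives 0.307 h in this assay, and the single step in hand, a 2.9-fold higher number from compound 1 to compound 2 (0.47 log units; beyond the scatter), is what sets compound 2 apart. Compound 3 `CC(C)NC(=O)CC(c1ccc(-c2ccc3cccc(F)c3c2)[nH]c1=O)C(C)C` is not yet measured in this assay; it differs from compound 2 by (isopropylcarbamoyl)methyl in place of 4H-1,2,4-triazol-3-yl on a saturated chain carbon bound to an aromatic carbon and a saturated chain carbon. The measured step concerns the 4H-1,2,4-triazol-3-yl and (4H-1,2,4-triazol-3-yl)methyl groups only, so it bears loosely on this exchange: it shows that a change of the group on the saturated chain carbon can move this assay beyond the scatter, but it gives no direction for an (isopropylcarbamoyl)methyl group. Going by the values given here, with no closer precedent, a step of a 1.8-fold lower number from compound 2 to compound 3 (0.26 log units; within the scatter) is expected, a modest drop held within a wide range. Compound 3 is estimated at 0.5 h in this assay, between 0.2 h and 1.5 h.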

Compound 3, half-life: 0.32 h
Beside the measured number, compound 3's estimate is 1.6-fold (0.19 log units) above it; the range from low to high includes it.
By their numbers in this assay, from the lowest: compounds 1 and 3 (each within the scatter of the next); then compound 2.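

In this assay, for the compounds shown here, the exchange to (isopropylcarbamoyl)methyl from 4H-1,2,4-triazol-3-yl gives a 2.8-fold lower number from compound 2 to compound 3 (0.45 log units; beyond the scatter) and so adds a second step beyond the scatter at this saturated chain carbon, the first with a group that has no ring. With isopropylcarbamoyl in place of 4H-1,2,4-triazol-3-yl on a saturated chain carbon, two bonds along the chain from an aromatic carbon, the result is a 1.0-fold higher number from compound 1 to compound 3 (0.02 log units; within the scatter) and the two groups cannot be told apart on this read-out, leaving compound 2 as the only one of the three that stands apart. Nothing in hand gives a cause for these steps.

Open, from the compounds shown here alone, is whether an amine or a carboxylic acid in place of 4H-1,2,4-triazol-3-yl on this carbon would read like compound 2 or like compound 3. Also open, going by these compounds, is how isopropylcarbamoyl bound directly to this carbon would read.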